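This account rests on a few compounds, and the source may have more. Where it says the series, first, only, none or still open, it means among the compounds named here.

Working notes on the series built on the shared core of compound 1 `CC(=O)N1CCN(C(=O)N2Cc3c(NC(=O)c4ccc(F)cc4)n[nH]c3C2(C)C)CC1`.

In a functional assay on A2780 cells (Homo sapiens) for antiproliferative activity, read by fluorescence, with a stated time of 72 h (a lower number here means a stronger inhibitor, a higher number a weaker inhibitor), compound 1 gives > 10000 nM. Among the compounds with values here, that reading is a limit of the assay, not a number, and it is the only entry for compound 1 at the limit of > 10000 nM in this assay, at which 1 of the 3 values shown sits. Compound 2 `CCN1CCC(C(=O)N2Cc3c(NC(=O)CC(C)C)n[nH]c3C2(C)C)CC1` differs from compound 1 in both the group on the ring nitrogen and the amide substituent, so the two are not a single-point comparison; in this assay compound 2 gives 410 nM. For compound 3 `CC1(C)c2[nH]nc(NC(=O)c3ccc(F)cc3)c2CN1C(=O)N1CCN(c2ccccc2)CC1` the entry in this assay reads "not determined" (no result reported), so no comparison can be drawn from it.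

Compound 4 `CC(C)(C)C(=O)N1Cc2c(NC(=O)c3ccc(F)cc3)n[nH]c2C1(C)C` is the compound to be measured next. It differs from compound 1 in one place: tert-butyl in place of 4-acetylpiperazin-1-yl on a carbonyl carbon. Within the data shown here, no measured step on the core involves this change, so its size and direction have to be estimated. Since compound 1 sits at the limit, any reported number for compound 4 would register as a gain; the step from compound 1 to compound 4 is expected to be an at least 2.5-fold lower number from compound 1 to compound 4 (0.39 log units; beyond the scatter), a modest move toward stronger inhibition with a real chance that only a limit is reported again. Compound 4 is therefore expected to give 4000 nM in this assay, within a range of 800 nM to 20000 nM.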

Compound 4, half-maximal inhibitory concentration: 270 nM
For compound 4 the middle estimate is 15-fold (1.17 log units) above the measured one, outside the stated range (below it).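

Within the data shown here, the step at this position is the first single-point comparison on the shared core: on a carbonyl carbon whose other neighbour is an amide-type nitrogen in a ring, tert-butyl in place of 4-acetylpiperazin-1-yl gives an at least 37-fold lower number from compound 1 to compound 4 (1.56 log units; beyond the scatter) in this assay. The reading for compound 1 is a limit of the assay and not a number, so the step gives only a lower bound on the size of the change: the limit of > 10000 nM in this assay, at which 1 of the 4 values shown sits. Tert-butyl has no ring and no hydrogen-bond acceptor, whereas 4-acetylpiperazin-1-yl has both, and this single step cannot show which of these differences, or the change in group size, goes with the lower number.

On these data alone, whether the gain is specific to tert-butyl remains open, and an isopropyl group, a dimethylamino group or a piperazine without the acetyl group on the same carbonyl carbon would help separate branching from the presence of the ring. As far as these compounds go, whether the change carries over to other amide substituents also remains open, as compound 2 differs from compound 4 in more than one place and compound 3 has no result.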